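Adding a 2-bromoethenyl group to the shared core

The compounds below may be only part of what the source reports. "The series", "measured", "known", "first", "only" and "open" are said of these compounds alone.

compound 1 `O=c1ccn(COCCO)c(=O)[nH]1` — > 400 ug/mL
compound 2 `Nc1nc(=O)n(COCCO)cc1[N+](=O)[O-]` — > 400 ug/mL

In a functional assay (Oryctolagus cuniculus) for inhibition (a lower number here means a stronger inhibitor, a higher number a weaker inhibitor), compound 1 gives > 400 ug/mL, which is a limit of the assay rather than a number. Compound 2 also gives > 400 ug/mL in this assay, again a limit. Every value here sits at the limit of > 400 ug/mL in this assay, at which 2 of the 2 values shown sit, so compound 1 stands at the limit, with nothing measured more finely.

Compound 3 `O=c1[nH]c(=O)n(COCCO)cc1/C=C/Br` differs from compound 1 by 2-bromoethenyl in place of hydrogen on an aromatic carbon. Going by the values given here, no measured step of this kind is at hand. Compound 3 is expected at 250 ug/mL, between 50 ug/mL and 400 ug/mL. The expected step is an at least 1.6-fold lower number from compound 1 to compound 3 (0.20 log units; that floor lies within the scatter), toward stronger inhibition, though another limit remains likely.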

Compound 3, concentration for 50% inhibition: > 200 ug/mL
Compound 3: only a limit was reported; the forecaster's own chance of this, stated with the estimate: 60%; the middle value lies beyond the limit too.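

Compound 1 and compound 3 are both reported only as limits of the assay, and the step between them cannot be read. Going by these compounds, whether 2-bromoethenyl in place of hydrogen changes inhibition in this assay remains open.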